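This account rests on a few compounds, and the source may have more. Where it says the series, first, only, none or still open, it means among the compounds named here.

In a functional assay on HCT-116 cells (Homo sapiens) for cytotoxicity, read by MTT assay, with a stated time of 72 h (a higher number here means a weaker inhibitor, a lower number a stronger inhibitor), compound 1 `COc1ncc(-c2ccc3nc(NC(=O)NCC(=O)N4CCCCC4)nn3c2)cc1NS(=O)(=O)c1ccc(F)cc1` gives 130 nM and compound 2 `CCN(CC)CCNC(=O)Nc1nc2ccc(-c3cnc(OC)c(NS(=O)(=O)c4ccc(F)cc4F)c3)cn2n1` gives 140 nM, two values within the scatter of each other. Compound 3 `CCN(CC)CCNC(=O)Nc1nc2ccc(-c3cnc(OC)c(NS(=O)(=O)c4ccc(Cl)cc4)c3)cn2n1` differs from compound 2 in one place, on a sulfonyl sulfur: 4-chlorophenyl in place of 2,4-difluorophenyl on a sulfonyl sulfur, with 4-chlorophenyl in place of 2,4-difluorophenyl. Within the data shown here, no step between measured compounds shows what this replacement does, so no shift beyond the scatter is expected in this assay, in either direction. The expected step is a 1.1-fold lower number from compound 2 to compound 3 (0.03 log units; within the scatter). The estimate for compound 3 is 130 nM, with an expected range of 50 nM to 350 nM.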

Compound 3, half-maximal inhibitory concentration: 120 nM
For compound 3 the middle estimate is 1.1-fold (0.03 log units) above the measured one; the range from low to high includes it.
By their numbers in this assay, from the lowest: compounds 3, 1 and 2 (each within the scatter of the next).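

In this assay, 4-chlorophenyl in place of 2,4-difluorophenyl on a sulfonyl sulfur gives the first step read at this position (a 1.2-fold lower number from compound 2 to compound 3 (0.07 log units; within the scatter)). The two groups therefore cannot be told apart here, so this change, with one chlorine entering and two fluorines leaving, leaves the cytotoxicity read-out unmoved. No measurement shown offers an explanation for this result. Still open, going by these compounds, is how an unsubstituted phenyl, a pyridine ring or a small alkyl group such as methyl on the sulfonyl sulfur would compare. On these data alone, whether the same replacement behaves alike with the piperidine urea chain of compound 1 also remains open.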